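This account rests on a few compounds, and the source may have more. Where it says the series, first, only, none or still open, it means among the compounds named here.

Measured in an ADME assay on CHO-K1 cells (Cricetulus griseus) for cytotoxicity, read by MTT assay, with a stated time of 24 h; a higher number here means that more compound is tolerated, a lower number that less compound is tolerated:
- compound 1 `S=C(Nc1ccccc1)Nc1ccc2[nH]ccc2c1`: 337000 nM
- compound 2 `S=C(Nc1ccc(Br)cc1)Nc1ccc2[nH]ccc2c1`: 220000 nM
- compound 3 `CC(=O)c1ccc(NC(=S)Nc2ccc3[nH]ccc3c2)cc1`: 154000 nM

Compound 1 stands at the top of these three numbers. Its nearest neighbour gives a 1.5-fold lower number from compound 1 to compound 2 (0.19 log units; within the scatter), and its furthest gives a 2.2-fold lower number from compound 1 to compound 3 (0.34 log units; beyond the scatter).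

Compound 4 `O=C(c1ccccc1)c1ccc(NC(=S)Nc2ccc3[nH]ccc3c2)cc1` is still unmeasured. The change is benzoyl in place of hydrogen on an aromatic carbon, para to a large group.

Compound 3 is the closest guide: its acetyl and the benzoyl of compound 4 both hold a carbonyl, and its step is a 2.2-fold lower number from compound 1 to compound 3 (0.34 log units; beyond the scatter). The bromo change is a weaker guide, at a 1.5-fold lower number from compound 1 to compound 2 (0.19 log units; within the scatter). The two substituted compounds are not separated, at a 1.4-fold lower number from compound 2 to compound 3 (0.15 log units; within the scatter). Going by the values given here, no measured compound carries benzoyl, so the size of the step remains uncertain.

In this assay, a modest fall is expected, in the same direction as the acetyl change and of similar size. The estimated step is a 2.6-fold lower number from compound 1 to compound 4 (0.41 log units; beyond the scatter). For compound 4 the estimated value is 130000 nM, with an expected range of 65000 nM to 260000 nM.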

Compound 4, concentration lethal to 50% of the cells: 20000 nM
Compound 4: the middle estimate sits 6.5-fold (0.81 log units) above what was measured; the measured number lies below the stated range.
By their numbers in this assay, from the lowest: compound 4; then compounds 3, 2 and 1 (each within the scatter of the next, the first and the last beyond it).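

In this assay, benzoyl on this aromatic carbon, para to a large group, lowers the tolerated concentration much further than the earlier changes did, with a 17-fold lower number from compound 1 to compound 4 (1.23 log units; beyond the scatter) and an 11-fold lower number from compound 2 to compound 4 (1.04 log units; beyond the scatter), so this position does respond strongly to at least one substituent. A carbonyl at this position is not enough to produce the full fall, since compound 3 also holds one, and phenyl in place of methyl on that carbonyl carbon still gives a 7.7-fold lower number from compound 3 to compound 4 (0.89 log units; beyond the scatter). Nothing available explains why the phenyl on the carbonyl carbon has this effect in cells.

As far as these compounds go, it remains open whether the aromatic ring alone carries the fall, which a phenyl group joined directly to the same carbon, without the carbonyl, would test, or whether the ring and carbonyl are needed together. Also unresolved is how a longer chain on the carbonyl carbon, such as butanoyl, or a benzoyl ring bearing a carboxylic acid or an amine would compare with compound 4 in this assay.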